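Pentyl for phenyl on the ring nitrogen of compound 2

The compounds below may be only part of what the source reports. "The series", "measured", "known", "first", "only" and "open" are said of these compounds alone.

Compound 2 `O=C(Nc1cccc(F)c1)c1cccc(/C=C2\CC(=O)N(c3ccccc3)C2=O)c1` was tested in an ADME assay on HCT-116 cells (Homo sapiens) for cytotoxicity, read by MTT assay, with a stated time of 72 h; on this read-out higher numbers stand for weaker inhibition and lower numbers for stronger inhibition. In this assay compound 2 gives > 100000 nM, which is a limit of the assay and not a number. Compound 1 `CCCCCN1C(=O)C/C(=C\c2cccc(C(=O)Nc3ccc(C)cc3)c2)C1=O` gives > 100000 nM in this assay, likewise a limit. Compound 3 `COc1ccc(OC)c(NC(=O)c2cccc(/C=C3\CC(=O)N(c4ccccc4)C3=O)c2)c1` gives > 100000 nM in this assay, again a limit. The step that the two limits leave unreadable from compound 2 to compound 3 is therefore unreadable, as the limit of > 100000 nM in this assay, at which 3 of the 3 values shown sit, shows for all three values. Compound 4 `CCCCCN1C(=O)C/C(=C\c2cccc(C(=O)Nc3cccc(F)c3)c2)C1=O` derives from compound 2 by pentyl in place of phenyl on an amide-type nitrogen in a ring. Among the measured compounds shown here, no measured step covers this change; compound 1, which also carries pentyl on an amide-type nitrogen in a ring, is itself reported only as a limit. No shift beyond the scatter is expected, a step that the limit leaves unreadable from compound 2 to compound 4. Compound 4 is expected to give 150000 nM (range 50000 nM to 500000 nM), most likely reported again as a limit.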

Compound 4, half-maximal inhibitory concentration: > 100000 nM
Compound 4 was reported as a limit; the forecaster's own chance of this, stated with the estimate: 85%; the middle value lies beyond the limit too.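

Compound 4 yields no readable step against compound 2 or compound 1, because all of them sit at one limit: the limit of > 100000 nM in this assay, at which 4 of the 4 values shown sit. On these data alone, whether pentyl in place of phenyl on the amide-type nitrogen in a ring changes cytotoxicity at all remains open.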